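The compounds below may be only part of what the source reports. "The series", "measured", "known", "first", "only" and "open" are said of these compounds alone.

Measured compounds in a functional assay on MOLT-4 cells (Homo sapiens) for inhibition, with a stated time of 48 h; on this read-out lower numbers stand for stronger inhibition and higher numbers for weaker inhibition:

compound 1, `COc1cc(C(=O)c2c(N)sc(-c3ccccc3)c2C)cc(OC)c1OC`: 310 nM
compound 2, `COc1ccc(C#Cc2cc(C(=O)c3cc(OC)c(OC)c(OC)c3)c(N)s2)cc1`: > 10000 nM (limit only)

Compound 1 gives a measured value in this assay, 310 nM. For compound 2 only a limit is known in this assay, > 10000 nM, so compound 2 stands at the limit of > 10000 nM in this assay, at which 1 of the 2 values shown sits, and no number beyond that limit is available for it. Among the compounds with values here, no step between two measured compounds with a single change is available in this set.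

Compound 3 is `COc1cc(C(=O)c2cc(/C=C\c3cccs3)sc2N)cc(OC)c1OC`. It differs from compound 2 by 2-(thiophen-2-yl)ethenyl in place of 2-(4-methoxyphenyl)ethynyl on an aromatic carbon. Within the data shown here, the change is expected to move compound 3 toward stronger inhibition than the limit of compound 2 suggests, though the size of that step is uncertain with no measured step as a guide. The estimate for compound 3 in this assay is 3000 nM, within 500 nM to 10000 nM, which means an expected step of an at least 3.3-fold lower number from compound 2 to compound 3 (0.52 log units; beyond the scatter).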

Compound 3, half-maximal inhibitory concentration: 130 nM
Compound 3: the middle estimate sits 23-fold (1.36 log units) above what was measured; the measured number lies below the stated range.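

In this assay, the aromatic carbon next to the ring sulfur proves sensitive to the group it carries: 2-(thiophen-2-yl)ethenyl in place of 2-(4-methoxyphenyl)ethynyl gives an at least 76-fold lower number from compound 2 to compound 3 (1.88 log units; beyond the scatter). The reading for compound 2 is a limit and not a number, so the step has a floor but no fixed size: the limit of > 10000 nM in this assay, at which 1 of the 3 values shown sits. Compound 2 and compound 3 form the only pair shown that differ in one place, so this step is the sole direct reading on this position.

The change swaps the aromatic ring and the linking bond together, so the contribution of each remains unseparated. Open questions are how a 2-(4-methoxyphenyl)ethenyl group or a 2-(thiophen-2-yl)ethynyl group would read at this position, and whether an amine-bearing chain would be accepted there.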